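A few compounds are considered here, and "the series" means these few. Any claim that something is new, unique, unknown or untested is made for them only; others in the source may bear on it.

Compound 3 `COc1c(C)cnc(C[S+]([O-])c2nnc(C)o2)c1C` is the simplest member of a small set. In a functional assay on HUVEC cells (Homo sapiens) for inhibition, read by ELISA (a higher number here means a weaker inhibitor, a lower number a stronger inhibitor), compound 3 gives 8000 nM. Compound 2 `COc1c(C)cnc(C[S+]([O-])c2nnc(-c3ccccc3O)o2)c1C` gives 8000 nM, and compound 1 `COc1c(C)cnc(C[S+]([O-])c2nnc(-c3cccn3C)o2)c1C` gives 4000 nM. Compound 3 therefore stands level with compound 2, the two sharing the highest number of the three, and the step of a 2.0-fold higher number from compound 1 to compound 3 (0.30 log units; within the scatter) lies within the scatter, as do a 2.0-fold higher number from compound 1 to compound 2 (0.30 log units; within the scatter) and no change at the digits printed from compound 2 to compound 3 (within the scatter). Every measured step swaps the group on the aromatic carbon of the shared core, and none of them moves the number beyond the scatter.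

Compound 4 `CCc1nnc([S+]([O-])Cc2ncc(C)c(OC)c2C)o1` differs from compound 3 in a different place: methyl in place of hydrogen on a saturated chain carbon bound to an aromatic carbon. Cut one bond further out, the change reads methyl to ethyl. Among the compounds with values here, no measured step touches this saturated chain carbon, so nothing bears on it directly; the only guide is that three quite different groups on the aromatic carbon gave numbers within the scatter of one another. A one-carbon growth on the chain is therefore expected to leave the number about where compound 3 sits, at 8000 nM, with no step beyond the scatter in either direction. Compound 4 is estimated at 8000 nM, with a range from 3000 nM to 20000 nM. The expected step is no change at the digits printed from compound 3 to compound 4 (within the scatter).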

Compound 4, half-maximal inhibitory concentration: 10000 nM
Compound 4: middle estimate off by 1.3-fold (0.10 log units), on the low side, and the stated range covers the measured number.
By their numbers in this assay, from the lowest: compounds 1, 2, 3 and 4 (each within the scatter of the next, the first and the last beyond it).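

In this assay, methyl in place of hydrogen on a saturated chain carbon bound to an aromatic carbon, which turns methyl into ethyl, gives a 1.3-fold higher number from compound 3 to compound 4 (0.10 log units; within the scatter), so this position now has a measured step, and that step cannot be told apart from ordinary repeat variation. Ethyl in place of 2-hydroxyphenyl gives a 1.3-fold higher number from compound 2 to compound 4 (0.10 log units; within the scatter), which also stays within that variation, whereas ethyl in place of 1-methyl-1H-pyrrol-2-yl gives a 2.5-fold higher number from compound 1 to compound 4 (0.40 log units; beyond the scatter), the only step in this small set to pass beyond the scatter, and only modestly. No supporting measurement is available to explain why compound 1 and compound 4 end up separated in this way.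

Going by these compounds, a single added carbon is a small test of this position, so it remains open whether a longer chain such as propyl or butyl would also leave the number within the scatter of compound 4. On these data alone, it is equally open whether an amine or a carboxylic acid at the end of that chain would shift the number in either direction, or by more than the steps seen so far.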